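Swapping the aryl group on the sulfone: compound 3 to 4

The source may hold more compounds than are shown below. What is called first, only, known or untested is meant among the compounds shown, and "the series" means these compounds.

Compound 3, `CC1CCN(c2c(S(=O)(=O)c3cccc(C#N)c3)cnc3cc(Cl)ccc23)CC1`, carries a 3-cyanophenyl on its sulfonyl sulfur. In an assay on isolated protein for displacement of a labelled ligand from metabotropic glutamate receptor 5 (Homo sapiens), with a stated time of 60 min, tested at 1 uM (on this read-out lower numbers stand for less inhibition and higher numbers for more inhibition at the one concentration tested (going by the name of the read-out)), compound 3 gives 94%. Its two measured relatives share the same core and differ only in that aryl group. Compound 1, `CC1CCN(c2c(S(=O)(=O)c3ccc(F)c(Cl)c3)cnc3cc(Cl)ccc23)CC1`, gives 94%, and compound 2, `CC1CCN(c2c(S(=O)(=O)c3ccccc3)cnc3cc(Cl)ccc23)CC1`, gives 93%. All three numbers sit within the scatter of one another: the step of no change at the digits printed from compound 1 to compound 3 (within the scatter), the step of a number 1 percentage points higher from compound 2 to compound 3 (within the scatter) and the step of a number 1 percentage points lower from compound 1 to compound 2 (within the scatter) are each too small to count as a real difference. Compound 3 is therefore level with compound 1 and indistinguishable from compound 2.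

Compound 4 is `CC1CCN(c2c(S(=O)(=O)c3ccc(Cl)c(Cl)c3)cnc3cc(Cl)ccc23)CC1`. The change from compound 3 is 3,4-dichlorophenyl in place of 3-cyanophenyl on a sulfonyl sulfur. The three measured steps all concern the same position on the sulfonyl sulfur, and none of them moved the read-out beyond the scatter, whether the aryl group was plain, carried a nitrile or carried two halogens. A step of no change at the digits printed from compound 3 to compound 4 (within the scatter) is expected for compound 4, that is, no change beyond the scatter. Compound 4 is estimated to give 94% in this assay, with a range from 86% to 99%.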

Compound 4, a percentage reported as inhibition, at one concentration (the size of the read-out at that concentration, not a potency): 89%
Compound 4: middle estimate off by 5 percentage points, on the high side; the measured number falls inside the stated range.
By their numbers in this assay, from the lowest: compounds 4, 2, 1 and 3 (each within the scatter of the next).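

With 3,4-dichlorophenyl on the sulfonyl sulfur, this assay gives three new steps to read: a number 5 percentage points lower from compound 3 to compound 4 (within the scatter) and a number 4 percentage points lower from compound 2 to compound 4 (within the scatter) and also a number 5 percentage points lower from compound 1 to compound 4 (within the scatter) for the swap of chloro in place of fluoro. Among these compounds, this extends what the earlier compounds showed, as the position now holds a plain phenyl, a nitrile-bearing ring and two different halogen-bearing rings with no step beyond the scatter, so the replacement of the nitrile-bearing ring by the dichlorinated one does not register as a real difference in this read-out. No measurement available here bears on why these numbers fall as they do.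

As far as these compounds go, all four compounds keep an aromatic carbon ring on the sulfonyl sulfur, so it remains open how a non-aromatic group such as a methyl, a cyclohexyl or an amine would fare there, or a phenyl carrying a carboxylic acid. A percentage at one concentration is also not a potency, so these four could still separate in a full concentration series.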